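The compounds below may be only part of what the source reports. "The series", "measured", "known", "first", "only" and "open" are said of these compounds alone.

Measured in a functional assay on DU-145 cells (Homo sapiens) for inhibition, read by trypan blue exclusion, with a stated time of 96 h; a lower number here means a stronger inhibitor of growth, a higher number a weaker inhibitor of growth:
- Compound 1 `O=C(/C(=C\c1ccc([N+](=O)[O-])c(O)c1)SCc1ccc(Br)cc1)c1ccc(Br)cc1`: 10000 nM
- Compound 2 `O=C(/C(=C\c1ccc(O)c(C(=O)O)c1)SCc1ccc(Br)cc1)c1ccc(Br)cc1`: 10000 nM
- Compound 3 `O=C(/C(=C\c1cc(Cl)c(O)c(Cl)c1)SCc1ccc(Br)cc1)c1ccc(Br)cc1`: 10000 nM

Compound 3 stands level with compound 1 and compound 2, so nothing in this small set separates yet. The next change gives compound 4 `O=C(/C(=C\c1cc(Br)c(O)c(Br)c1)SCc1ccc(Br)cc1)c1ccc(Br)cc1`: 3,5-dibromo-4-hydroxyphenyl in place of 3,5-dichloro-4-hydroxyphenyl on a double-bonded chain carbon bound to a double-bonded chain carbon. Three measured steps altered the group at this same place: no change at the digits printed from compound 1 to compound 2 (within the scatter), no change at the digits printed from compound 1 to compound 3 (within the scatter) and no change at the digits printed from compound 2 to compound 3 (within the scatter). For the measured compounds named here, none of them moved the number, although no measured step swaps chlorine for bromine directly. The swap in compound 4 therefore gives no reason to expect a shift in this assay beyond the scatter. The expected change is no change at the digits printed from compound 3 to compound 4 (within the scatter). Compound 4 is estimated at 10000 nM, with an expected range of 4000 nM to 20000 nM.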

Compound 4, concentration for 50% growth inhibition: 1000 nM
Compound 4: middle estimate off by 10-fold (1.00 log units), on the high side, and the stated range ends above it.
By their numbers in this assay, from the lowest: compound 4; then compounds 1, 2 and 3 (each within the scatter of the next).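

In this assay this place on the chain is not silent: the halogen itself matters, since 3,5-dibromo-4-hydroxyphenyl in place of 3,5-dichloro-4-hydroxyphenyl gives a 10-fold lower number from compound 3 to compound 4 (1.00 log units; beyond the scatter) with the same count of heavy atoms. The other two groups show the same picture, with a 10-fold lower number from compound 2 to compound 4 (1.00 log units; beyond the scatter) and a 10-fold lower number from compound 1 to compound 4 (1.00 log units; beyond the scatter) as well, so only the dibromo compound separates from a set that otherwise sat level. Nothing available explains the difference between bromine and chlorine here.

The compounds shown leave open whether iodine or a methyl group in place of the two bromines would lower the number further. They also leave open whether the hydroxyl is needed alongside the bromines.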